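Compound 4 in the cytotoxicity series

A few compounds are considered here, and "the series" means these few. Any claim that something is new, unique, unknown or untested is made for them only; others in the source may bear on it.

Compound 1 `COC(=O)c1ccc(NCc2cncn2Cc2ccccc2N)cc1-c1ccccc1`: 25000 nM
Compound 2 `COC(=O)c1ccc(NCc2cncn2Cc2ccc(C(C)(C)C)cc2)cc1-c1ccccc1`: "not determined" (no result reported)
Compound 3 `COC(=O)c1ccc(NCc2cncn2Cc2cccc(Cl)c2)cc1-c1ccccc1`: > 10000 nM (a limit)

These three compounds were examined in a toxicity assay on NIH3T3 cells (Mus musculus) for cytotoxicity, read by resazurin assay; a higher number here means that more compound is needed for the effect, a lower number that less compound is needed. Compound 3 has only a limit, > 10000 nM, and not a number. This is the limit of > 10000 nM in this assay, at which 1 of the 3 values shown sits. Compound 2 has no usable result, "not determined" (no result reported).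

The next compound, compound 4 `COC(=O)c1ccc(NCc2cncn2Cc2ccccc2[N+](=O)[O-])cc1-c1ccccc1`, has this structural change: 2-nitrophenyl in place of 3-chlorophenyl on a saturated chain carbon bound to an aromatic nitrogen. In words, it has 2-nitrophenyl in place of 3-chlorophenyl on a saturated chain carbon bound to an aromatic nitrogen.

Within the data shown here, one measured step bears on this place: a step that the limit leaves unreadable from compound 1 to compound 3. Its size therefore gives no guide to the size of the next step. Among the measured compounds shown here, the only number at this place belongs to compound 1, which carries 2-aminophenyl and gives 25000 nM. In this assay, a value in that same region is therefore expected, with no firm direction from compound 3. The expected step is a step that the limit leaves unreadable from compound 3 to compound 4. For compound 4 the estimated value is 20000 nM, with an expected range of 7000 nM to 50000 nM.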

Compound 4, half-maximal effective concentration: 10000 nM
Compound 4: the middle estimate sits 2.0-fold (0.30 log units) above what was measured; the measured number falls inside the stated range.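

In this assay, among these compounds, the change of amino to nitro on an aromatic carbon gives the first step at this position that can be read: a 2.5-fold lower number from compound 1 to compound 4 (0.40 log units; beyond the scatter). This shows that exchanging this one group on the benzyl substituent moves the number beyond the usual scatter, although only modestly. Compound 3 has only a limit, > 10000 nM, and not a number. The new step that touches this limit is a number no higher from compound 3 to compound 4 (the limit leaves the size open) and the steps that involve the limit cannot be read, because of this: the limit of > 10000 nM in this assay, at which 1 of the 4 values shown sits.

As far as these compounds go, how 3-chlorophenyl truly compares with 2-nitrophenyl or 2-aminophenyl therefore stays open. The compounds shown also leave open whether a carboxylic acid or a methoxy group in place of the nitro would continue the downward step from amino to nitro or reverse it.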